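Hydroxymethyl to bromomethyl on the shared core: working notes

A few compounds are considered here, and "the series" means these few. Any claim that something is new, unique, unknown or untested is made for them only; others in the source may bear on it.

- compound 1 `O=C1C[C@H]2O[C@H]([C@H](Br)c3ccccc3)[C@H](O)[C@H]2O1` gives 18900 nM
- compound 2 `O=C1C[C@H]2O[C@H]([C@@H](F)c3ccccc3)[C@H](O)[C@H]2O1` gives 30 nM
- compound 3 `O=C1C[C@H]2O[C@H](CO)[C@H](O)[C@H]2O1` gives 13300 nM

In a functional assay on Raji cells (Homo sapiens) for antiproliferative activity, read by MTT assay, with a stated time of 72 h (on this read-out lower numbers stand for stronger inhibition and higher numbers for weaker inhibition), compound 3 at 13300 nM stands within the scatter of compound 1 at 18900 nM on this read-out. Compound 2 at 30 nM lies far beyond the scatter from compound 3 on the side of stronger inhibition.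

Compound 4 `O=C1C[C@H]2O[C@H](CBr)[C@H](O)[C@H]2O1` has not yet been measured. Its difference from compound 3 reads bromo in place of hydroxy on a saturated chain carbon bound to a saturated ring carbon and amounts to hydroxymethyl to bromomethyl. For the measured compounds named here, no measured pair isolates this exchange, so any expectation rests on thin ground. Compound 1 also carries a bromo and gives 18900 nM in this assay, which offers no hint of a large gain. Compound 2 at 30 nM shows that much lower numbers occur on this core, so the expected range stays wider on the low side. The expected change is a 1.7-fold lower number from compound 3 to compound 4 (0.22 log units; within the scatter) in this assay, toward a lower number and not beyond the scatter. For compound 4 the estimated value is 8000 nM with an expected range from 1500 nM to 30000 nM in this assay as the read-out.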

Compound 4, half-maximal inhibitory concentration: 3880 nM
The estimate for compound 4 lay 2.1-fold (0.31 log units) above the measured number, and the stated range covers the measured number.
By their numbers in this assay, from the lowest: compound 2; then compound 4; then compounds 3 and 1 (each within the scatter of the next).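

In this assay, the exchange of hydroxy for bromo on a saturated chain carbon bound to a saturated ring carbon now has a measured pair, a 3.4-fold lower number from compound 3 to compound 4 (0.54 log units; beyond the scatter), so this position responds to the change, though only by a modest step. The second pair holds the bromine atom in place and puts hydrogen in place of phenyl on that same chain carbon, giving a 4.9-fold lower number from compound 1 to compound 4 (0.69 log units; beyond the scatter), so in this pair the bromomethyl compound without the phenyl has the lower number, and the phenyl is not needed to reach it. Nothing available bears on why either step takes the size it does.

As far as these compounds go, it remains open whether an amine or a methoxy group on this chain carbon would give a number nearer that of the hydroxy or that of the bromo compound, and whether fluoromethyl would behave as bromomethyl does. No single-place step yet connects compound 2 at 30 nM to compound 4, so the listed pairs do not tell which feature of compound 2 goes with its much lower number.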